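Plasma half-life notes on the shared core: compound 4

The compounds below may be only part of what the source reports. "The series", "measured", "known", "first", "only" and "open" are said of these compounds alone.

Measured so far in an ADME assay on a cell-free system (plasma, Homo sapiens) for metabolic stability, with Plasma (Rattus norvegicus) as the target, read by HPLC, at pH 7.4; on this read-out higher numbers stand for a longer-lived compound and lower numbers for a shorter-lived compound:
compound 1 `CC(=O)Oc1ccccc1C(=O)O[C@H]1CO[C@H]2[C@@H]1OC[C@H]2OC(=O)C1CC1` gives 0.0322 h
compound 2 `CC(=O)Oc1ccccc1C(=O)O[C@H]1CO[C@H]2[C@@H]1OC[C@H]2OC(=O)c1ccc([N+](=O)[O-])cc1` gives 0.0462 h
compound 3 `CC(=O)Oc1ccccc1C(=O)O[C@H]1CO[C@H]2[C@@H]1OC[C@H]2OC(=O)c1cnccc1Cl` gives 0.0642 h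

Compound 1 holds the lowest of the three numbers, but neither neighbour is separated from it beyond the scatter: a 1.4-fold higher number from compound 1 to compound 2 (0.16 log units; within the scatter) and a 2.0-fold higher number from compound 1 to compound 3 (0.30 log units; within the scatter). Between the two aryl esters the gap is likewise small, a 1.4-fold higher number from compound 2 to compound 3 (0.14 log units; within the scatter). All three half-lives therefore sit in one narrow band.

Compound 4 `CC(=O)Oc1ccccc1C(=O)O[C@H]1CO[C@H]2[C@@H]1OC[C@H]2OC(=O)c1cccc(CO[N+](=O)[O-])c1` is not yet measured. Relative to compound 1 the change is 3-((nitrooxy)methyl)phenyl in place of cyclopropyl on a carbonyl carbon.

The two steps that bear on this one are those in which cyclopropyl gave way to an aromatic ring on the same carbonyl carbon, from compound 1 to compound 2 and from compound 1 to compound 3. Both moved the half-life upward, both stayed within the scatter. On that basis a small upward step, not clearly beyond the scatter, is expected for compound 4: a 1.6-fold higher number from compound 1 to compound 4 (0.19 log units; within the scatter). The estimated half-life of compound 4 in this assay is 0.05 h, with a likely range from 0.025 h to 0.1 h. For the measured compounds named here, no measured step involves the 3-((nitrooxy)methyl)phenyl group itself, so the range is kept wide.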

Compound 4, half-life: 0.0433 h
The estimate for compound 4 lay 1.2-fold (0.06 log units) above the measured number; low and high end bracket the measured number.
By their numbers in this assay, from the lowest: compounds 1, 4, 2 and 3 (each within the scatter of the next).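

In this assay, the carbonyl carbon position takes the 3-((nitrooxy)methyl)phenyl group, far larger than cyclopropyl, with no step beyond the scatter: a 1.3-fold higher number from compound 1 to compound 4 (0.13 log units; within the scatter). The comparisons with the two other aromatic esters read the same way, a 1.5-fold lower number from compound 3 to compound 4 (0.17 log units; within the scatter) and a 1.1-fold lower number from compound 2 to compound 4 (0.03 log units; within the scatter), so a nitrooxy-bearing group does not separate from 4-nitrophenyl or 4-chloropyridin-3-yl. With cyclopropyl and three different aromatic groups now all within the scatter of one another, no group at this position stands apart in half-life, and nothing available speaks to the reason for this flat picture.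

Still open, as far as these compounds go, is whether any group on this carbonyl carbon can move the half-life clearly beyond the scatter, for instance a ring carrying an amine or a carboxylic acid, or a longer alkyl chain in place of the ring. Also open, from the compounds shown here alone, is how much of the short half-life belongs to the part common to all four compounds, since the acetyloxy benzoate ester on the shared core stays the same throughout.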